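Loss of a methyl on the cyanoguanidine chain end

The compounds below may be only part of what the source reports. "The series", "measured", "known", "first", "only" and "open" are said of these compounds alone.

Measured so far:
compound 1, `C/N=C(/NC#N)NCCCCCCn1nc(-c2ccccc2)ccc1=O`: 31.7%
compound 2, `O=c1ccc(-c2ccccc2)nn1CCCC/N=C(\S)Nc1ccc(S(=O)(=O)O)cc1`: 25.1%
compound 3, `C/N=C(/NC#N)NCCCn1nc(-c2ccccc2)c(C)cc1=O`: 17.2%

These three compounds were tested in a functional assay on the whole organism with Rattus norvegicus as the target, at a dose of 100 mg/kg; a higher number here means more inhibition at the dose given (going by the name of the read-out), a lower number less inhibition. Compound 1 gives 31.7%, the largest of the three numbers. Compound 2 gives 25.1%, which lies within the usual scatter of compound 1, so the two cannot be told apart. Compound 3 gives 17.2%, a number that sits beyond the scatter below compound 1.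

The next compound, compound 4, `N#CNC(=N)NCCCCCCn1nc(-c2ccccc2)ccc1=O`, has not yet been measured in this assay. It differs from compound 1 in one place: a group of 5 heavy atoms (2 carbon, 3 nitrogen; no ring) in place of a group of 6 heavy atoms (3 carbon, 3 nitrogen; no ring), on an amine nitrogen. In plain terms, a methyl on the nitrogen at the end of the cyanoguanidine is gone and a hydrogen stands there instead, while the rest of the molecule is unchanged.

For the measured compounds named here, no pair of measured compounds shows the effect of this particular change, so the expected step from compound 1 to compound 4 can only be guessed. A small change of this kind is expected to give a step of a number 4.7 percentage points lower from compound 1 to compound 4 (within the scatter) in this assay, most likely not beyond the scatter in either direction. Compound 4 is therefore estimated to give 27%, with a range from 12% to 42%.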

Compound 4, a percentage reported as inhibition, in the whole organism at one dose (the size of the read-out at that dose, not a potency): 20.5%
Beside the measured number, compound 4's estimate is 6.5 percentage points above it; the measured number falls inside the stated range.
By their numbers in this assay, from the lowest: compounds 3, 4, 2 and 1 (each within the scatter of the next, the first and the last beyond it).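

For the compounds shown here, this is the first pair in the set that differs in one place only, so the effect of a single change can now be read directly. In this assay, replacing the methyl at the end of the cyanoguanidine with a hydrogen, on an amine nitrogen whose other neighbour is a saturated chain carbon, gives a number 11.2 percentage points lower from compound 1 to compound 4 (beyond the scatter), so even the loss of this one methyl is visible at this position. By the computed counts, the entering group has one more hydrogen-bond donor than the group it replaces and the same number of hydrogen-bond acceptors, but nothing measured here says what lies behind the lower number.

From the compounds shown here alone, whether a larger group on this nitrogen, such as an ethyl or a cyclopropyl, would raise or lower the number remains open, since a single step shows only that a methyl and a hydrogen differ here. Going by these compounds, it is also open whether removing this methyl would have a similar effect in a compound with a different chain and core, such as compound 3 , or at doses other than the one used here.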